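Chain-end variation on the shared core: working notes

This account rests on a few compounds, and the source may have more. Where it says the series, first, only, none or still open, it means among the compounds named here.

Three compounds on the shared core have numbers in a functional assay (aorta) with Rattus norvegicus as the target; a higher number here means a weaker inhibitor, a lower number a stronger inhibitor. Compound 1 `C/N=C(/S)[C@@]1(c2cccnc2)CCCC[C@@H]1CC#N` gives 300 nM. Compound 2 `C/N=C(/S)[C@@]1(c2cccnc2)CCCC[C@@H]1CCOC(C)=O` gives 30 nM. Compound 3 `C/N=C(/S)[C@@]1(c2cccnc2)CCCC[C@@H]1CCOC(=O)c1ccc(F)cc1` gives 100 nM. Compound 2 holds the lowest number of the three: compound 3 is nearest to it and compound 1 furthest, and both gaps lie beyond the scatter. The steps into and out of compound 2 are a 10-fold lower number from compound 1 to compound 2 (1.00 log units; beyond the scatter) and a 3.3-fold higher number from compound 2 to compound 3 (0.52 log units; beyond the scatter), both modest.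

Compound 4 `C/N=C(/S)[C@@]1(c2cccnc2)CCCC[C@@H]1CCNS(C)(=O)=O` is not yet measured. It differs from compound 2 by methanesulfonamido in place of acetoxy on a saturated chain carbon, two bonds along the chain from a saturated ring carbon. Both measured steps alter the same chain and so bear on this change: the first put acetoxymethyl in place of cyano and lowered the number, the second put 4-fluorophenyl in place of methyl on the carbonyl carbon and raised it. Among the measured compounds shown here, neither settles the direction for a methanesulfonamido end, and no measured compound carries that group. The expectation for compound 4 is therefore a step of about the size seen so far, more likely upward than downward, so a 2.0-fold higher number from compound 2 to compound 4 (0.30 log units; within the scatter) is the estimated step. Compound 4 is estimated at 60 nM, with a range from 15 nM to 300 nM.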

Compound 4, concentration for 90% inhibition: 170 nM
Compound 4: the middle estimate sits 2.8-fold (0.45 log units) below what was measured; measured number inside the range.
By their numbers in this assay, from the lowest: compound 2; then compounds 3, 4 and 1 (each within the scatter of the next, the first and the last beyond it).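

Methanesulfonamido does not keep the low number of the acetoxy end: in this assay the change gives a 5.7-fold higher number from compound 2 to compound 4 (0.75 log units; beyond the scatter), a step beyond the scatter, with 1 hydrogen-bond donor entering where acetoxy has 0. Set against the nitrile end, the same chain gives a 1.8-fold lower number from compound 1 to compound 4 (0.25 log units; within the scatter), so compound 4 cannot be told apart from compound 1 and shows none of the clear separation seen in a 10-fold lower number from compound 1 to compound 2 (1.00 log units; beyond the scatter). Compound 2 therefore remains separated from each of the other three compounds on this chain, but nothing available explains why methanesulfonamido and acetoxy differ here.

The compounds shown do not separate the effect of the sulfonyl group from that of the nitrogen, which an acetamide end with nitrogen in place of the ester oxygen, or a sulfonamide with a methyl group on its nitrogen, would begin to address. Also open, on these data alone, is how this chain end behaves with a longer chain, or with a free hydroxyl or a carboxylic acid at its terminus.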